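Cytotoxicity of a urea series: estimating an unmeasured analogue

This account rests on a few compounds, and the source may have more. Where it says the series, first, only, none or still open, it means among the compounds named here.

Measured compounds:
compound 1 `CN(C)CCn1cnnc1-c1cc(Oc2ccc(NC(=O)N/N=C/c3ccc(F)cc3)cc2F)ccn1`, 3980 nM
compound 2 `CN(C)CCn1cnnc1-c1cc(Oc2ccc(NC(=O)N/N=C/c3ccc(F)cc3F)cc2F)ccn1`, 5030 nM

In an ADME assay on WI-38 cells (Homo sapiens) for cytotoxicity, read by MTT assay, with a stated time of 72 h (on this read-out higher numbers stand for weaker inhibition and lower numbers for stronger inhibition), compound 1 gives 3980 nM, and compound 2 gives 5030 nM. In this assay compound 3 `COc1cc(/C=N/NC(=O)Nc2ccc(Oc3ccnc(-c4nncn4CCN(C)C)c3)c(F)c2)cc(OC)c1OC` has the entry "not determined" (no result reported), so no number stands for it. Compound 2 holds the highest of the two numbers, yet its step of a 1.3-fold higher number from compound 1 to compound 2 (0.10 log units; within the scatter) lies within the scatter, so the two cannot be ordered. Compound 4 `COc1cc(/C=N/NC(=O)Nc2ccc(Oc3ccnc(-c4nncn4CCN(C)C)c3)c(F)c2)ccc1O` differs from compound 2 by 4-hydroxy-3-methoxyphenyl in place of 2,4-difluorophenyl on a carbon with a double bond to nitrogen. For the measured compounds named here, no measured step touches this position, so nothing in the numbers points either way. Compound 4 is therefore expected to stay close to compound 2, with the estimated step of a 1.0-fold lower number from compound 2 to compound 4 (0.00 log units; within the scatter) not going beyond the scatter. The estimate for compound 4 is 5000 nM, within 2000 nM to 12000 nM.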

Compound 4, half-maximal inhibitory concentration: 5320 nM
For compound 4 the middle estimate is 1.1-fold (0.03 log units) below the measured one; the measured number falls inside the stated range.
By their numbers in this assay, from the lowest: compounds 1, 2 and 4 (each within the scatter of the next).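

Until now, this position had varied only by fluoro in place of hydrogen on the ring. Compound 4 brings a larger change, with 4-hydroxy-3-methoxyphenyl carrying hydrogen-bond donor and acceptor groups that 2,4-difluorophenyl and 4-fluorophenyl lack, yet the read-out barely registers it (a 1.1-fold higher number from compound 2 to compound 4 (0.02 log units; within the scatter); a 1.3-fold higher number from compound 1 to compound 4 (0.13 log units; within the scatter)). No evidence here explains this outcome.

As far as these compounds go, only aromatic rings have been compared on this carbon, so it remains open whether a ring bearing an amine or a carboxylic acid, or a longer alkyl chain in place of the ring, would also leave the number within the scatter.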